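Hydroxyethyl replacement in the amine head group

The source may hold more compounds than are shown below. What is called first, only, known or untested is meant among the compounds shown, and "the series" means these compounds.

Two compounds of this series carry numbers in an assay on CHO cells for agonist activity at 5-hydroxytryptamine receptor 1D (Homo sapiens), read by GTPgammaS binding; a lower number here means that less compound is needed, a higher number that more compound is needed for the effect. Compound 1 `COC[C@H](NC1CCN(CCCc2c[nH]c3ccc(Cn4cncn4)cc23)CC1)c1ccc(F)cc1` gives 8.9 nM, the lowest of the two, and compound 2 `C[C@@H](NC1CCN(CCCc2c[nH]c3ccc(-n4cnnc4)cc23)CC1)c1ccccc1` gives 13 nM, a gap that sits within the scatter of the measurement, so no order between the two is read from it. For the measured compounds named here, compound 2 differs from compound 1 both at the amine head group and at the substituent on the shared core, so no single step between measured compounds is at hand.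

Compound 3 `OC[C@H](NC1CCN(CCCc2c[nH]c3ccc(Cn4cncn4)cc23)CC1)c1ccccc1` is not yet measured. It differs from compound 1 in one place: 2-hydroxy-1-phenylethyl in place of 1-(4-fluorophenyl)-2-methoxyethyl on an amine nitrogen. Going by the values given here, no measured pair isolates this exchange, so nothing in the numbers fixes its size; the only guide is that compound 2, with another amine head group on a related core, stays within the scatter of compound 1. The step from compound 1 to compound 3 is expected to be small, a modest rise if anything, as given by a 1.7-fold higher number from compound 1 to compound 3 (0.23 log units; within the scatter). Compound 3 is estimated at 15 nM, with a range from 5 nM to 45 nM.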

Compound 3, half-maximal effective concentration: 32 nM
For compound 3 the middle estimate is 2.1-fold (0.33 log units) below the measured one, and the stated range covers the measured number.
By their numbers in this assay, from the lowest: compounds 1 and 2 (each within the scatter of the next); then compound 3.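

For the compounds shown here, the exchange of 1-(4-fluorophenyl)-2-methoxyethyl for 2-hydroxy-1-phenylethyl on an amine nitrogen gives the first single-place step: in this assay it amounts to a 3.6-fold higher number from compound 1 to compound 3 (0.56 log units; beyond the scatter), so this position does respond to a change in the group it carries. The step is a combined one, since the leaving group has a fluorine and no hydrogen-bond donor while the entering group has a hydrogen-bond donor and no fluorine, and a single pair cannot divide its size between these differences. No measurement at hand bears on the reason for this rise.

Which part of the exchange carries the step remains open: 2-methoxy-1-phenylethyl and 1-(4-fluorophenyl)-2-hydroxyethyl on the same amine nitrogen would each separate one difference from the other. Also open, going by these compounds, is how a 2-amino-1-phenylethyl or a 2-carboxy-1-phenylethyl group would read at this position in this assay, and whether the size of the step carries over to another substituent on the shared core.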